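This account rests on a few compounds, and the source may have more. Where it says the series, first, only, none or still open, it means among the compounds named here.

Measured in a functional assay on ECa-109 cells for inhibition, with ECa-109 cell line (Homo sapiens) as the target, read by sulforhodamine B assay; a lower number here means a stronger inhibitor, a higher number a weaker inhibitor:
Compound 1 `COc1cccc(NC2=CC(=O)c3nc4n(c3C2=O)[C@H]2OC[C@@H](O)[C@H]2OC4)c1` gives 7620 nM.
Compound 2 `O=C1C=C(NC2CCCC2)C(=O)c2c1nc1n2[C@H]2OC[C@@H](O)[C@H]2OC1` reaches only the assay's limit, > 16000 nM.
Compound 3 `O=C1C=C(Nc2ccccc2F)C(=O)c2c1nc1n2[C@H]2OC[C@@H](O)[C@H]2OC1` gives 2760 nM.

Compound 3 has the lowest number of the two actual values, with a 2.8-fold lower number from compound 1 to compound 3 (0.44 log units; beyond the scatter) setting it apart from compound 1. Compound 4 `O=C1C=C(N2CCCC2)C(=O)c2c1nc1n2[C@H]2OC[C@@H](O)[C@H]2OC1` differs from compound 3 by pyrrolidin-1-yl in place of (2-fluorophenyl)amino on a double-bonded ring carbon. Within the data shown here, the steps that bear on this change are an at least 5.7-fold lower number from compound 2 to compound 3 (0.76 log units; beyond the scatter) and an at least 2.0-fold higher number from compound 1 to compound 2 (0.32 log units; beyond the scatter), both of which show the saturated ring giving the higher number, with compound 2 sitting at the limit of > 16000 nM in this assay, at which 1 of the 3 values shown sits. Compound 4 is therefore expected to move the same way as a 5.4-fold higher number from compound 3 to compound 4 (0.74 log units; beyond the scatter), toward a weaker inhibitor. The estimate for compound 4 in this assay is 15000 nM, expected to lie between 5000 nM and 40000 nM.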

Compound 4, half-maximal inhibitory concentration: > 16000 nM
Compound 4 gave a limit, no number (the forecaster's own chance of this, stated with the estimate: 45%); middle value at least 1.0-fold (0.02 log units) away from the limit.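

In this assay, compound 4 stops at a limit, not a number, so a second non-aromatic group joins cyclopentylamino there: the limit of > 16000 nM in this assay, at which 2 of the 4 values shown sit.

The readable steps are an at least 5.7-fold higher number from compound 3 to compound 4 (0.76 log units; beyond the scatter) and an at least 2.0-fold higher number from compound 1 to compound 4 (0.32 log units; beyond the scatter), and they show that a ring with 0 hydrogen-bond donors, attached through its own nitrogen, also falls short of the (2-fluorophenyl)amino and (3-methoxyphenyl)amino groups at this double-bonded ring carbon.

The step between compound 2 and compound 4 cannot be read, as both values are limits. As far as these compounds go, it stays open whether the aromatic ring or the amine hydrogen matters more here, and a methyl(phenyl)amino group on this carbon would bear on that.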